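Hydrogen in place of 3-methoxyphenyl: notes on compound 4

A few compounds are considered here, and "the series" means these few. Any claim that something is new, unique, unknown or untested is made for them only; others in the source may bear on it.

In an ADME assay on NIH3T3 cells (Mus musculus) for inhibition, read by sulforhodamine B assay, with a stated time of 48 h (a higher number here means a weaker inhibitor of growth, a lower number a stronger inhibitor of growth), the measured compounds read as follows:
- compound 1 `O=C(NNC(=O)c1ccc2[nH]c(-c3ccc([N+](=O)[O-])o3)nc2c1)c1ccccc1` gives 31.3 ug/mL
- compound 2 `COc1cc(C(=O)NNC(=O)c2ccc3[nH]c(-c4ccc([N+](=O)[O-])s4)nc3c2)cc(OC)c1OC` gives 31.3 ug/mL
- compound 3 `COc1cccc(C(=O)NNC(=O)c2ccc3[nH]c(-c4ccc([N+](=O)[O-])o4)nc3c2)c1` gives 15.6 ug/mL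

Compound 3 stands within the scatter of both compound 1 and compound 2, so the three values do not separate. Next comes compound 4 `O=CNNC(=O)c1ccc2[nH]c(-c3ccc([N+](=O)[O-])o3)nc2c1`, with hydrogen in place of 3-methoxyphenyl on a carbonyl carbon, so that (3-methoxyphenyl)carbonyl becomes formyl: hydrogen in place of 3-methoxyphenyl on a carbonyl carbon. Within the data shown here, one measured step bears on this, and only weakly: a 2.0-fold lower number from compound 1 to compound 3 (0.30 log units; within the scatter), for methoxy in place of hydrogen on an aromatic carbon. Among the measured compounds shown here, that step leaves the six-membered aromatic ring in place, and no measured compound lacks this ring, so the data do not fix the size or direction of the new step. Nothing beyond the scatter is firmly expected in this assay, and the estimated step is a 1.6-fold higher number from compound 3 to compound 4 (0.20 log units; within the scatter) with real uncertainty on both sides. For compound 4 the estimated value is 25 ug/mL, with 8 ug/mL to 80 ug/mL as the expected range.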

Compound 4, concentration for 50% growth inhibition: 62.5 ug/mL
Estimate against measurement, compound 4: 2.5-fold (0.40 log units) below, within the range that was stated.
By their numbers in this assay, from the lowest: compounds 3, 1, 2 and 4 (each within the scatter of the next, the first and the last beyond it).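

Among these compounds, at the carbonyl carbon, in this assay, hydrogen in place of 3-methoxyphenyl gives the only step that lies beyond the scatter (a 4.0-fold higher number from compound 3 to compound 4 (0.60 log units; beyond the scatter)). Hydrogen in place of phenyl at the same carbon stays within the scatter (a 2.0-fold higher number from compound 1 to compound 4 (0.30 log units; within the scatter)), so loss of the aromatic ring separates the values only in the pair that carries the methoxy group. Nothing available accounts for this difference between the two steps.

As far as these compounds go, it remains open whether a small alkyl group such as methyl, or a saturated ring such as cyclohexyl, on this carbonyl carbon would read with the formyl compound 4 or with the aryl compounds 1 and 3. From the compounds shown here alone, an amine or a carboxylic acid on the six-membered aromatic ring is equally open.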